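Swapping the Aryl Group on a Shared Core

The compounds below may be only part of what the source reports. "The series", "measured", "known", "first", "only" and "open" are said of these compounds alone.

Compound 1, `Cc1cc(=O)oc2cc(OCc3nc(N)nc(Nc4ccc(C(C)C)cc4)n3)ccc12`, gives 460 nM in an assay on COS-7 cells for agonist activity at Free fatty acid receptor 1 (Homo sapiens), read by scintillation counting and inositol phosphate accumulation, with a stated time of 90 min; on this read-out higher numbers stand for an effect only at larger amounts of compound and lower numbers for an effect already at smaller amounts.
Compound 2, `Cc1ccc(Nc2nc(N)nc(COc3ccc4c(C)cc(=O)oc4c3)n2)cc1C`, gives 210 nM in this assay.

Going by the values given here, of the two measured compounds, compound 1 has the higher number; the only comparison is the step of a 2.2-fold lower number from compound 1 to compound 2 (0.34 log units; beyond the scatter), which goes beyond the scatter. Compound 3, `Cc1c(Cl)cc(Nc2nc(N)nc(COc3ccc4c(C)cc(=O)oc4c3)n2)cc1Cl`, is not yet measured. It differs from compound 1 in one place: 3,5-dichloro-4-methylphenyl in place of 4-isopropylphenyl on a nitrogen on an aromatic ring. Among the compounds with values here, the sole step that bears on this change is the one from compound 1 to compound 2, where another aryl group replaced the 4-isopropylphenyl on the same nitrogen and gave a modest lowering. Within the data shown here, a similar modest lowering is therefore expected for compound 3, though with a wide range given the single precedent. Compound 3 is estimated at 220 nM, between 70 nM and 700 nM, which means an expected step of a 2.1-fold lower number from compound 1 to compound 3 (0.32 log units; beyond the scatter).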

Compound 3, half-maximal effective concentration: 600 nM
For compound 3 the middle estimate is 2.7-fold (0.44 log units) below the measured one; measured number inside the range.
By their numbers in this assay, from the lowest: compound 2; then compounds 1 and 3 (each within the scatter of the next).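

In this assay, 3,5-dichloro-4-methylphenyl in place of 4-isopropylphenyl on this nitrogen gives a 1.3-fold higher number from compound 1 to compound 3 (0.12 log units; within the scatter), so this exchange leaves the two compounds indistinguishable. Against 3,4-dimethylphenyl the same group gives a 2.9-fold higher number from compound 2 to compound 3 (0.46 log units; beyond the scatter), which shows that the earlier lowering belongs to 3,4-dimethylphenyl and does not carry over to every replacement of 4-isopropylphenyl at this position. Nothing available here accounts for this difference between the two aryl groups.

The compounds shown leave open how an unsubstituted phenyl, or an aryl group carrying a carboxylic acid or an amine, would read at this nitrogen. They also leave open whether the order of these aryl groups would hold on a core other than the shared one.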